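Shortening the chain of compound 1

The source may hold more compounds than are shown below. What is called first, only, known or untested is meant among the compounds shown, and "the series" means these compounds.

Measured so far in a functional assay on MCF7 cells (Homo sapiens) for inhibition, read by MTT assay, with a stated time of 72 h (a higher number here means a weaker inhibitor, a lower number a stronger inhibitor), are two compounds.
Compound 1 `Nc1nc2cc(-c3nn(CCCCCCCCCC(=O)NO)c4ncnc(N)c34)ccc2o1` gives > 50000 nM as a limit
Compound 2 `Nc1ncnc2c1c(-c1cnc3[nH]ccc3c1)nn2CCCCCCCCCC(=O)NO` gives 23200 nM as a number

Among the compounds with values here, compound 1 stands at a limit of the assay with > 50000 nM as its only reading. Compound 3 `Nc1nc2cc(-c3nn(CCCCC(=O)NO)c4ncnc(N)c34)ccc2o1` shares its core and differs in the chain hydroxycarbamoyl in place of 5-(hydroxycarbamoyl)pentyl on a saturated chain carbon, four bonds along the chain from an aromatic nitrogen at that one place. Within the data shown here, the only measured step of an at least 2.1-fold lower number from compound 1 to compound 2 (0.33 log units; beyond the scatter) changes the aromatic group and leaves the chain alone, so it guides the expected size only loosely. In this assay a modest move toward a lower number is expected, with an at least 2.5-fold lower number from compound 1 to compound 3 (0.39 log units; beyond the scatter) as the estimated step. For compound 3 the estimated value is 20000 nM with 3000 nM to 60000 nM as its expected range.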

Compound 3, half-maximal inhibitory concentration: 14000 nM
Compound 3: the middle estimate sits 1.4-fold (0.15 log units) above what was measured; low and high end bracket the measured number.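

In this assay, hydroxycarbamoyl in place of 5-(hydroxycarbamoyl)pentyl, on a saturated chain carbon, gives an at least 3.5-fold lower number from compound 1 to compound 3 (0.55 log units; beyond the scatter), with the core unchanged. Within the data shown here, the earlier step changed only the aromatic group, and this is the first one showing that the chain at this place also moves the number. The reading for compound 1 is a limit, and the full size of the step stays unknown because of it: the limit of > 50000 nM in this assay, at which 1 of the 3 values shown sits.

The compounds shown leave open how chains of intermediate length, such as 2-(hydroxycarbamoyl)ethyl, would read. They also leave open whether a carboxylic acid could replace the hydroxycarbamoyl end.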